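The source may report more compounds than this note shows. Statements on the series, on what has been measured and on what is new or still open speak of the compounds shown alone.

Measured compounds:
- compound 1 `O=CN1CCN(c2ccc(Cl)cc2)C1=S`: 27000 nM
- compound 2 `O=C(c1ccco1)N1CCCN(C(=O)c2ccco2)C1=S`: 36000 nM
- compound 3 `O=C(c1ccccc1)N1CCCN(C(=O)c2ccccc2)C1=S`: limit, > 100000 nM

Three compounds carry the shared core of compound 1, each read in a functional assay on MT4 cells (Homo sapiens) for antiproliferative activity, read by MTT assay; a higher number here means a weaker inhibitor, a lower number a stronger inhibitor. Compound 1 gives 27000 nM, the lower of the two numbers reported. Compound 2 sits nearest with 36000 nM, a gap that lies within the usual scatter, so the two cannot be told apart. Compound 3 returns only a limit of the assay, > 100000 nM, and gives no number; this is the case noted in the limit of > 100000 nM in this assay, at which 1 of the 3 values shown sits.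

For the measured compounds named here, no pair among the measured compounds differs in a single place, so no measured step is available. The next compound, compound 4 `O=CN1CCN(c2ccc(Cl)c(Cl)c2)C1=S`, departs from compound 1 by one change: chloro in place of hydrogen on an aromatic carbon.

Going by the values given here, with no measured step to lean on, only a small move is expected here, if any beyond the scatter, and the direction is left open, with a slight lean toward a lower number. For compound 4 in this assay the estimate is 20000 nM, within 7000 nM to 60000 nM, which means an expected step of a 1.4-fold lower number from compound 1 to compound 4 (0.13 log units; within the scatter).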

Compound 4, half-maximal inhibitory concentration: 41000 nM
Compound 4: the middle estimate sits 2.1-fold (0.31 log units) below what was measured; the range from low to high includes it.
By their numbers in this assay, from the lowest: compounds 1, 2 and 4 (each within the scatter of the next). At a limit, above all of these: compound 3.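

The series now has its first measured single change in this assay (a 1.5-fold higher number from compound 1 to compound 4 (0.18 log units; within the scatter)). The step lies within the scatter, so on this evidence the added chloro group, ortho to a chloro group and meta to a group of 8 heavy atoms, leaves compound 1 and compound 4 indistinguishable. The reading covers one substituent at one position on the core of compound 1, and no available data bear on the reason for this result.

From the compounds shown here alone, whether an amine, a carboxylic acid or a methoxy group at the same carbon would move the number beyond the scatter remains open. Also open, going by these compounds, is what the existing chloro group of compound 1 contributes, since no single-place comparison for that group is at hand.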